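Halogen Swap and Amino Loss in Mouse Microsomal Clearance

The source may hold more compounds than are shown below. What is called first, only, known or untested is meant among the compounds shown, and "the series" means these compounds.

Four close relatives share one skeleton: compound 1 `Nc1n[nH]c2cc(-c3ccc(=O)n(Cc4cccc(Cl)c4)c3)ccc12`, compound 2 `Nc1n[nH]c2cc(-c3ccc(=O)n(Cc4cccc(F)c4)c3)ccc12`, compound 3 `O=c1ccc(-c2ccc3cn[nH]c3c2)cn1Cc1cccc(Cl)c1` and compound 4 `O=c1ccc(-c2ccc3cn[nH]c3c2)cn1Cc1cccc(F)c1`. The first three have been run in an ADME assay on microsomes (Mus musculus) for metabolic stability, read by LC-MS, using NADPH, with a stated time of 1 h, tested at 1 uM; a higher number here means faster removal of the compound, a lower number slower removal. In this assay compound 1 gives < 10 mL.min-1.g-1, which is a limit of the assay rather than a number. Compound 2 likewise gives < 10 mL.min-1.g-1, again a limit. Going by the values given here, compound 3 gives 52 mL.min-1.g-1, the only full number of the three. The change from compound 1 to compound 2 is fluoro in place of chloro on an aromatic carbon, and its step is a step that the two limits leave unreadable from compound 1 to compound 2 because both values sit at the limit of < 10 mL.min-1.g-1 in this assay, at which 2 of the 3 values shown sit. The two cores differ by hydrogen in place of amino on an aromatic carbon, and that step is an at least 5.2-fold higher number from compound 1 to compound 3 (0.71 log units; beyond the scatter). Compound 4 carries the same change on the core of compound 3: fluoro in place of chloro on an aromatic carbon, at the same place as before. The earlier step offers no size to carry over, so the expectation rests on compound 3 and its number 52 mL.min-1.g-1. For compound 4 the expected step is a 1.2-fold lower number from compound 3 to compound 4 (0.06 log units; within the scatter), set beside the unreadable earlier one. Compound 4 is estimated at 45 mL.min-1.g-1, between 20 mL.min-1.g-1 and 100 mL.min-1.g-1.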

Compound 4, intrinsic clearance in microsomes: 160 mL.min-1.g-1
Compound 4: the middle estimate sits 3.6-fold (0.55 log units) below what was measured; the measured number lies above the stated range.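

In this assay, fluoro in place of chloro gives a readable step on the core lacking the amino group, a 3.1-fold higher number from compound 3 to compound 4 (0.49 log units; beyond the scatter). On the amino-bearing core the same swap cannot be read, so the series does not show whether the step carries from one core to the other, and compound 1 and compound 2 show only that both sit at a limit of the assay rather than at a number: the limit of < 10 mL.min-1.g-1 in this assay, at which 2 of the 4 values shown sit. Hydrogen in place of amino, by contrast, goes the same way with either halogen, with the fluoro pair giving an at least 16-fold higher number from compound 2 to compound 4 (1.20 log units; beyond the scatter), although the sizes on the two cores cannot be told apart: the same change on two cores in this assay, an at least 5.2-fold higher number (0.71 log units; beyond the scatter) from compound 1 to compound 3 and an at least 16-fold higher number (1.20 log units; beyond the scatter) from compound 2 to compound 4; the limit leaves it open whether they differ.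

The compounds shown leave open how a methyl group, a methoxy group or a nitrile would read in place of the halogen on the core of compound 3. They also leave open whether a hydroxyl group or a methyl group in place of the amino group would read closer to compound 1 or to compound 3.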